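Replacing 2-phenylethenyl with cyclopropyl on a sulfonyl sulfur

The compounds below may be only part of what the source reports. "The series", "measured", "known", "first", "only" and "open" are said of these compounds alone.

Of the compounds shown here, two have been measured so far. In a functional assay on MDA-MB-231 cells (Homo sapiens) for antiproliferative activity, read by MTT assay, with a stated time of 48 h (a higher number here means a weaker inhibitor, a lower number a stronger inhibitor), compound 1 (`C=CS(=O)(=O)N1CCN(c2ncnc3sc(-c4ccc(OC)cc4)cc23)CC1`) gives 29900 nM and compound 2 (`CN1CCN(c2ccc(-c3cc4c(N5CCN(S(=O)(=O)/C=C/c6ccccc6)CC5)ncnc4s3)cc2)CC1`) gives 5900 nM as the lower of the two numbers, a gap beyond the usual scatter. Compound 2 is thus the stronger inhibitor of this pair. The two compounds differ in more than one place, so their gap cannot be assigned to any single group.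

Compound 3 (`CN1CCN(c2ccc(-c3cc4c(N5CCN(S(=O)(=O)C6CC6)CC5)ncnc4s3)cc2)CC1`) departs from compound 2 in one group only, with cyclopropyl in place of 2-phenylethenyl on a sulfonyl sulfur. Within the data shown here, no measured pair isolates this change, so the expectation starts from compound 2 at 5900 nM and from the structural change alone. In this assay, among the measured compounds shown here, no step clearly beyond the scatter is expected, though the number is expected to lean higher, and the estimated step is (a 1.5-fold higher number from compound 2 to compound 3 (0.18 log units; within the scatter)). The expected value for compound 3 is 9000 nM with an estimated range (3500 nM to 25000 nM).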

Compound 3, half-maximal inhibitory concentration: 11500 nM
The estimate for compound 3 lay 1.3-fold (0.11 log units) below the measured number; the range from low to high includes it.
By their numbers in this assay, from the lowest: compounds 2 and 3 (each within the scatter of the next); then compound 1.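

In this assay, putting cyclopropyl in place of 2-phenylethenyl gives a 1.9-fold higher number from compound 2 to compound 3 (0.29 log units; within the scatter), and this is the first step among these compounds that isolates a single group. On a sulfonyl sulfur whose other neighbours are a sulfonamide nitrogen in a ring, the 8 heavy atoms of 2-phenylethenyl, with its six-membered aromatic ring and its double bond outside aromatic rings, can thus be exchanged for the 3 heavy atoms of cyclopropyl without a difference that stands clear of the scatter, so this assay does not separate the two groups. Nothing at hand offers an explanation for how closely the two groups read here.

The compounds shown leave open whether a methyl group, a longer chain such as n-butyl or a chain ending in an amine on the same sulfonyl sulfur would also read like these two groups. They also leave open how a plain phenyl group at this place would compare, as well as a carbonyl in place of the sulfonyl group itself.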